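Same chlorine shift on a second core: an expectation

This account rests on a few compounds, and the source may have more. Where it says the series, first, only, none or still open, it means among the compounds named here.

Measured in a functional assay on MDA-MB-231 cells (Homo sapiens) for cytotoxicity, read by MTT assay, with a stated time of 72 h; on this read-out higher numbers stand for weaker inhibition and lower numbers for stronger inhibition:
compound 1 `CN(C)CCNc1nc(-c2ccc(NC(=O)Nc3ccc(Cl)cc3)cc2)nc2ccsc12` gives 310 nM
compound 2 `CN(C)CCNc1nc(-c2ccc(NC(=O)Nc3ccccc3Cl)cc2)nc2ccsc12` gives 550 nM
compound 3 `CCN(CC)CCNc1nc(-c2ccc(NC(=O)Nc3ccc(Cl)cc3)cc2)nc2c(Cl)c(Cl)sc12` gives 750 nM

Compound 1 and compound 2 share one core and differ in a single place: 2-chlorophenyl in place of 4-chlorophenyl on an amide-type nitrogen. That change gave a 1.8-fold higher number from compound 1 to compound 2 (0.25 log units; within the scatter). Compound 3 carries a different core; how the two cores differ is not broken down here. Compound 4 `CCN(CC)CCNc1nc(-c2ccc(NC(=O)Nc3ccccc3Cl)cc2)nc2c(Cl)c(Cl)sc12` is not yet measured and repeats the same change on the core of compound 3: 2-chlorophenyl in place of 4-chlorophenyl on an amide-type nitrogen. For the measured compounds named here, the step in this assay from compound 3 to compound 4 is expected to be a 1.7-fold higher number from compound 3 to compound 4 (0.24 log units; within the scatter), a single prior instance being the only guide, because compound 1 to compound 2 gave a 1.8-fold higher number from compound 1 to compound 2 (0.25 log units; within the scatter). Compound 4 is accordingly estimated at 1300 nM, expected to lie between 600 nM and 3000 nM.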

Compound 4, half-maximal inhibitory concentration: 1410 nM
Estimate against measurement, compound 4: 1.1-fold (0.04 log units) below; the range from low to high includes it.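

On the core of compound 3, 2-chlorophenyl in place of 4-chlorophenyl on the amide-type nitrogen gave, in this assay, a 1.9-fold higher number from compound 3 to compound 4 (0.27 log units; within the scatter). Each of the two steps lies within the scatter, so they do not establish that the change has a real effect on either core, and two pairs say nothing about any further core. What they do show is that the step came out alike on both cores: the same change on two cores in this assay, a 1.8-fold higher number (0.25 log units; within the scatter) from compound 1 to compound 2 and a 1.9-fold higher number (0.27 log units; within the scatter) from compound 3 to compound 4, 1.1-fold (0.03 log units) apart, within the scatter of two such steps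

The compounds shown leave open how the same comparison would run with an unsubstituted phenyl or a methoxyphenyl on that nitrogen. They also leave open whether it would hold with a morpholine or a longer chain in place of the amine side chain.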